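This account rests on a few compounds, and the source may have more. Where it says the series, first, only, none or still open, it means among the compounds named here.

Two compounds of this series carry numbers in an assay on isolated protein for inhibition of aldehyde dehydrogenase 1A1 (Homo sapiens), read by spectrophotometry, tested at 10 uM (on this read-out higher numbers stand for more inhibition at the one concentration tested (going by the name of the read-out) and lower numbers for less inhibition), so far. Compound 1 `O=C(C1CC1)N1CCN(Cc2nc3ccccc3n2Cc2ccccc2C(F)(F)F)CC1` gives 56.3% there. Compound 2 `CC(C)Cn1c(CN2CCN(C(=O)C3CC3)CC2)nc2ccccc21` gives 13.1% and stands as the lower of the two. Going by the values given here, the single measured step, isopropyl in place of 2-(trifluoromethyl)phenyl on a saturated chain carbon bound to an aromatic nitrogen, amounts to a number 43.2 percentage points lower from compound 1 to compound 2 (beyond the scatter). Compound 3 `CCCCn1c(CN2CCN(C(=O)C3CC3)CC2)nc2ccccc21` is the next member and has not been measured. It differs from compound 2 in one place: propyl in place of isopropyl on a saturated chain carbon bound to an aromatic nitrogen. Among the compounds with values here, no measured step bears directly on this change; the one between compound 1 and compound 2 concerns 2-(trifluoromethyl)phenyl against isopropyl and says nothing about propyl against isopropyl. Compound 3 is therefore expected to stay close to compound 2, with a step of about a number 2.9 percentage points higher from compound 2 to compound 3 (within the scatter), not beyond the scatter. Compound 3 is estimated at 16%, within a range from 3% to 35%.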

Compound 3, a percentage reported as inhibition, at one concentration (the size of the read-out at that concentration, not a potency): 18.2%
For compound 3 the middle estimate is 2.2 percentage points below the measured one; the measured number falls inside the stated range.
By their numbers in this assay, from the lowest: compounds 2 and 3 (each within the scatter of the next); then compound 1.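

Rearranging the same atoms at this place, with propyl in place of isopropyl on a saturated chain carbon bound to an aromatic nitrogen, leaves this assay without a separation between the two alkyl compounds (a number 5.1 percentage points higher from compound 2 to compound 3 (within the scatter)). The large distance from compound 1 is therefore not particular to the isopropyl group, since the unbranched group shows it too (a number 38.1 percentage points lower from compound 1 to compound 3 (beyond the scatter)). Nothing available explains this distance between the 2-(trifluoromethyl)phenyl group and either alkyl group.

The compounds shown leave open whether the higher number of compound 1 depends on the trifluoromethyl group or on the aromatic ring that carries it. An unsubstituted phenyl or a cyclohexyl at this place would separate those two readings, and a longer chain would extend the alkyl comparison.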